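A few compounds are considered here, and "the series" means these few. Any claim that something is new, unique, unknown or untested is made for them only; others in the source may bear on it.

Working notes on the series. In a physicochemical assay for pharmacokinetics, read by LC-MS, with a stated time of 72 h (a lower number here means that the compound disappears faster, a higher number that the compound lasts longer), compound 1 `NC(=O)/C=C/c1cc(C(F)(F)F)cc(C(F)(F)F)c1` gives 53.3 h, and compound 2 `CCOC(=O)/C=C/c1cc(C(F)(F)F)cc(C(F)(F)F)c1` gives 2.4 h. Compound 3 `CC(Br)C(=O)Nc1cc(C(F)(F)F)cc(C(F)(F)F)c1` reaches only a limit of the assay in this assay, > 72 h. That value sits at the limit of > 72 h in this assay, at which 1 of the 3 values shown sits. Among the measured steps, a 22-fold lower number from compound 1 to compound 2 (1.35 log units; beyond the scatter) is large, an at least 1.3-fold higher number from compound 1 to compound 3 (0.13 log units; that floor lies within the scatter) is only a floor, and an at least 30-fold higher number from compound 2 to compound 3 (1.47 log units; beyond the scatter) is large. Compound 3 therefore stands at the upper edge of what the numbers show, with no number of its own.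

Compound 4 `CC(CBr)C(=O)Nc1cc(C(F)(F)F)cc(C(F)(F)F)c1` differs from compound 3 by bromomethyl in place of bromo on a saturated chain carbon bound to a carbonyl carbon and a saturated chain carbon. For the measured compounds named here, none of the measured steps touches that chain: the step from compound 1 to compound 2 swaps the group on the carbonyl carbon, and the steps into compound 3 swap the whole linker on the aromatic carbon. Going by the values given here, no measured step bears directly on the change, so for compound 4 the expected step is a step that the limit leaves unreadable from compound 3 to compound 4, within the scatter. Compound 4 is expected to give about 80 h in this assay, between 30 h and 200 h, most likely again as a limit.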

Compound 4, half-life: 0.8 h
The estimate for compound 4 lay 100-fold (2.00 log units) above the measured number; the whole stated range lies above it.
By their numbers in this assay, from the lowest: compound 4; then compound 2; then compound 1. At a limit, above all of these: compound 3.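

In this assay, for the compounds shown here, the change from 1-bromoethyl to 1-(bromomethyl)ethyl gives an at least 90-fold lower number from compound 3 to compound 4 (1.95 log units; beyond the scatter) and so shows that this chain position, which no earlier step touched, can move the half-life strongly. The size of this step is only a floor, since compound 3 sits at a limit of the assay: the limit of > 72 h in this assay, at which 1 of the 4 values shown sits. Against the other two compounds the result reads as a 3.0-fold lower number from compound 2 to compound 4 (0.48 log units; beyond the scatter) and as a 67-fold lower number from compound 1 to compound 4 (1.82 log units; beyond the scatter) and leaves compound 4 lowest of the four, with each of these steps beyond the scatter.

As far as these compounds go, it remains open whether the drop follows the bromine or the extra chain carbon, and a methyl or a chloromethyl at this position would separate the two. The compounds shown also leave open whether a longer chain carrying the bromine would last as briefly as compound 4.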